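The source may report more compounds than this note shows. Statements on the series, on what has been measured and on what is new or still open speak of the compounds shown alone.

Compound 1 `Nc1c(C2=NCCN2)cnn1-c1cccc(Cl)c1` carries one chloro group on the aryl ring and a five-membered ring on the shared core. In an ADME assay on Vero cells (Chlorocebus sabaeus) for cytotoxicity, read by CellTiter-Glo and ATP content, with a stated time of 72 h (on this read-out higher numbers stand for lower toxicity in this test and lower numbers for higher toxicity in this test), compound 1 gives only a limit of the assay, > 500000 nM. Compound 2 `Nc1c(C2=NCCN2)cnn1-c1ccc(Cl)c(Cl)c1` differs from compound 1 by chloro in place of hydrogen on an aromatic carbon; in this assay compound 2 gives 244000 nM, a step of an at least 2.0-fold lower number from compound 1 to compound 2 (0.31 log units; beyond the scatter). Compound 3 `Nc1c(C2=NCCCN2)cnn1-c1cccc(Cl)c1` differs from compound 1 in the core by a group of 6 heavy atoms (4 carbon, 2 nitrogen; one six-membered non-aromatic ring with 2 hetero atoms) in place of a group of 5 heavy atoms (3 carbon, 2 nitrogen; one five-membered non-aromatic ring with 2 hetero atoms), on an aromatic carbon. In this assay compound 3 also gives only a limit of the assay, > 500000 nM. The step that the two limits leave unreadable from compound 1 to compound 3 therefore cannot be sized, and the limit of > 500000 nM in this assay, at which 2 of the 3 values shown sit, marks where both sit. Compound 4 `Nc1c(C2=NCCCN2)cnn1-c1cc(Cl)cc(Cl)c1`, not yet measured, differs from compound 3 by chloro in place of hydrogen on an aromatic carbon. This is the same kind of change as from compound 1 to compound 2, though the surroundings differ: there the entering chloro is ortho to a chloro group and para to a large group, here it is meta to a chloro group and meta to a large group. For compound 4 the expected step in this assay is an at least 1.6-fold lower number from compound 3 to compound 4 (0.22 log units; that floor lies within the scatter). This expectation rests on the step of an at least 2.0-fold lower number from compound 1 to compound 2 (0.31 log units; beyond the scatter) seen for the same kind of change, while the starting point of compound 3 is only a limit. The estimate for compound 4 is 300000 nM, between 120000 nM and 700000 nM.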

Compound 4, half-maximal cytotoxic concentration: > 500000 nM
Compound 4: no number, only a limit; the forecaster's own chance of this, stated with the estimate: 40%; middle value at least 1.6-fold (0.22 log units) from the limit.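

In this assay compound 4 gives only a limit, > 500000 nM. No step can be read from compound 3 to compound 4, because both stand at the same limit: the limit of > 500000 nM in this assay, at which 3 of the 4 values shown sit.

The compounds shown leave open whether chloro in place of hydrogen on the aryl ring of compound 3 changes the read-out at all.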